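Swapping a Small Ring for a Larger One

The compounds below may be only part of what the source reports. "The series", "measured", "known", "first", "only" and "open" are said of these compounds alone.

Compound 1 `CCOC(=O)c1cnc(NC2CC2)n2nc(-c3ccco3)nc12` is the reference point of this small set. For the measured compounds named here, in an assay on CHO cells for displacement of a labelled ligand from adenosine receptor A3 (Homo sapiens) (on this read-out lower numbers stand for stronger inhibition and higher numbers for weaker inhibition), compound 1 gives 9.52 nM, the lowest of the three numbers measured so far. Compound 2 `CCOC(=O)c1cnc(NCc2ccc(F)cc2)n2nc(-c3ccco3)nc12` gives 46.3 nM in this assay, and compound 3 `CCOC(=O)c1cnc(NCCOC)n2nc(-c3ccco3)nc12` gives 105 nM. Both bind more weakly than compound 1: a 4.9-fold higher number from compound 1 to compound 2 (0.69 log units; beyond the scatter), and an 11-fold higher number from compound 1 to compound 3 (1.04 log units; beyond the scatter). Between the two weaker compounds, a 2.3-fold higher number from compound 2 to compound 3 (0.36 log units; beyond the scatter).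

Compound 4 `CCOC(=O)c1cnc(NC2CCCCC2)n2nc(-c3ccco3)nc12` has not yet been measured. It differs from compound 1 in one place: cyclohexyl in place of cyclopropyl on a nitrogen on an aromatic ring. The two measured steps that bear on this change are a 4.9-fold higher number from compound 1 to compound 2 (0.69 log units; beyond the scatter) and an 11-fold higher number from compound 1 to compound 3 (1.04 log units; beyond the scatter), since each of them also replaced the cyclopropyl on that nitrogen, and each gave a higher number. Neither replacement was a ring of carbon only, so the guidance is loose, but the direction is consistent. A modest rise in the number is therefore expected, a 3.2-fold higher number from compound 1 to compound 4 (0.50 log units; beyond the scatter). Compound 4 is estimated to give 30 nM in this assay, with a range from 8 nM to 120 nM.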

Compound 4, inhibition constant: 131 nM
The estimate for compound 4 lay 4.4-fold (0.64 log units) below the measured number, outside the stated range (above it).
By their numbers in this assay, from the lowest: compound 1; then compound 2; then compounds 3 and 4 (each within the scatter of the next).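

With a ring of carbon only on that nitrogen, the low number of compound 1 is still lost: cyclohexyl in place of cyclopropyl gives a 14-fold higher number from compound 1 to compound 4 (1.14 log units; beyond the scatter) in this assay and counts as a large step. So a carbon ring at this position is not enough in itself, and ring size matters here. Cyclohexyl also cannot be separated from 2-methoxyethyl, given a 1.2-fold higher number from compound 3 to compound 4 (0.10 log units; within the scatter) within the scatter, while a 2.8-fold higher number from compound 2 to compound 4 (0.45 log units; beyond the scatter) puts it on the weaker side of 4-fluorobenzyl. No measurement at hand gives a reason for these differences.

Two ring sizes cannot show whether the number climbs steadily as the ring grows or jumps at some size. Cyclobutyl and cyclopentyl on the same nitrogen would settle that, and a small open chain such as isopropyl would show whether a ring is needed at all.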